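The compounds below may be only part of what the source reports. "The series", "measured", "known", "first", "only" and "open" are said of these compounds alone.

Measured compounds in a functional assay on A549 cells (Homo sapiens) for cytotoxicity, read by MTT assay, with a stated time of 6 days; on this read-out lower numbers stand for an effect already at smaller amounts and higher numbers for an effect only at larger amounts of compound:

- compound 1 `C/C1=C\CCC2=C[C@H](OC2=O)C(C(C)(C)O)CC/C(C)=C/CC1`: its value is a limit of the assay, > 50 ug/mL the limit of > 50 ug/mL in this assay, at which 1 of the 3 values shown sits.
- compound 2 `CC(=O)OC(C)(C)C1CC/C(C)=C/CC/C(C)=C/CCC2=C[C@@H]1OC2=O`: 3.03 ug/mL
- compound 3 `C=C(C)C1CC[C@@]2(C)CCC[C@@](C)(OC(C)=O)[C@@H]2C1`: 0.12 ug/mL

Compound 3 gives the lowest of the two numbers in this assay; the nearest number belongs to compound 2, which sits well apart from it, beyond the scatter. Compound 1 is represented only by a limit and not by a number.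

Compound 4 `C=C(C)C1CC[C@@]2(C)CCC[C@@](C)(O)[C@@H]2C1` is not yet measured in this assay. It differs from compound 3 in one place: hydrogen in place of acetyl on an oxygen on a saturated carbon.

Within the data shown here, one measured step bears on this change, in the opposite direction: an at least 16-fold lower number from compound 1 to compound 2 (1.21 log units; beyond the scatter). That step reads acetyl in place of hydrogen on an oxygen on a saturated carbon and gave a markedly lower number, though the size is only known as a bound because compound 1 stands at a limit. Taking the step from compound 3 to compound 4 as the reverse, a large move towards higher numbers in this assay is expected for compound 4, the estimated step being a 21-fold higher number from compound 3 to compound 4 (1.32 log units; beyond the scatter).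

Compound 4 is therefore expected to give about 2.5 ug/mL in this assay, within a range of 0.6 ug/mL to 12 ug/mL.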

Compound 4, concentration for half-maximal effect: > 50 ug/mL
Compound 4 ended at the assay's limit; the forecaster's own chance of this, stated with the estimate: 10%; at least 20-fold (1.30 log units) between middle value and limit.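

The change from acetoxy to hydroxy, on an oxygen on a saturated carbon, now has a reading on a second core in this assay: it gives an at least 410-fold higher number from compound 3 to compound 4 (2.61 log units; beyond the scatter). The value of compound 4 is a limit of the assay, so this step is known only as a bound. Taken with the step on the core of compound 1, acetyl goes with the lower number on both cores, and no compound shown goes against this, though the two sizes cannot be compared: the same change on two cores in this assay, an at least 16-fold lower number (1.21 log units; beyond the scatter) from compound 1 to compound 2 and an at least 410-fold lower number (2.61 log units; beyond the scatter) from compound 4 to compound 3; the limit leaves it open whether they differ

From the compounds shown here alone, how far the two hydroxy compounds, compound 1 and compound 4, lie beyond the limit stays open, and with it the true size of both steps. Also open, going by these compounds, is whether the lower number is tied to acetyl alone or also appears with a longer ester such as propionyl, or with a methyl ether on the same oxygen.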